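The compounds below may be only part of what the source reports. "The series", "measured", "known", "first", "only" and "open" are said of these compounds alone.

Three compounds share one core and differ only at the outer ring of their ketone arm. Compound 1 `COc1cc(-c2nnc(SCC(=O)c3ccccc3)n2N)cc(OC)c1OC` carries the plain phenyl ketone; in a functional assay on PC-3 cells (Homo sapiens) for antiproliferative activity, read by MTT assay, with a stated time of 48 h (a higher number here means a weaker inhibitor, a lower number a stronger inhibitor), compound 1 gives > 100000 nM, which is a limit of the assay rather than a number. Compound 2 `COc1cc(-c2nnc(SCC(=O)c3ccc(Br)cc3)n2N)cc(OC)c1OC` has bromo in place of hydrogen on that ring, and in this assay compound 2 gives > 100000 nM, again a limit. Compound 3 `COc1cc(-c2nnc(SCC(=O)c3ccc(F)cc3)n2N)cc(OC)c1OC` has fluoro in place of hydrogen there, and in this assay compound 3 gives > 100000 nM, also a limit. Compound 3 therefore stands exactly where the other two stand, at the limit of > 100000 nM in this assay, at which 3 of the 3 values shown sit. The measured steps, a step that the two limits leave unreadable from compound 1 to compound 2, a step that the two limits leave unreadable from compound 1 to compound 3 and a step that the two limits leave unreadable from compound 2 to compound 3, all run between limits and reveal no size.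

Compound 4 `COc1cc(-c2nnc(SCC(=O)Nc3ccccc3)n2N)cc(OC)c1OC` is the next compound. Against compound 3 the change is anilino in place of 4-fluorophenyl on a carbonyl carbon, so the ketone becomes an amide. For the measured compounds named here, none of the measured steps touches the carbonyl carbon, so none bears directly on this change, and each was unreadable in any case. The step from compound 3 to compound 4 is expected to be a number no higher from compound 3 to compound 4 (the limit leaves the size open), most likely ending again at a limit. Compound 4 is estimated at 100000 nM in this assay, within 30000 nM to 300000 nM.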

Compound 4, half-maximal inhibitory concentration: 37900 nM
The estimate for compound 4 lay 2.6-fold (0.42 log units) above the measured number; measured number inside the range.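

For the compounds shown here, for the first time the series gives a readable change in this assay: replacing the aryl group on the carbonyl carbon with anilino, which turns the ketone into an amide, gives an at least 2.6-fold lower number from compound 3 to compound 4 (0.42 log units; beyond the scatter), an at least 2.6-fold lower number from compound 2 to compound 4 (0.42 log units; beyond the scatter) and an at least 2.6-fold lower number from compound 1 to compound 4 (0.42 log units; beyond the scatter). Each of these is only a lower bound, with its true size left open by the limit at its start, yet all three lie beyond the usual scatter, so the carbonyl carbon is a place where a change moves the read-out, whereas the steps among the ketones, which carry hydrogen, bromo or fluoro on the outer ring, cannot be read. Going by these compounds alone, compound 4 is thus the one compound here with a true number, and the other three stay where they were: the limit of > 100000 nM in this assay, at which 3 of the 4 values shown sit.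

The compounds shown cannot tell whether the amide hydrogen itself matters, since that would take a comparison with a group such as N-methylanilino. Nor do they tell how a benzylamino group would compare, or whether bromo or fluoro on the anilino ring would shift the number.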